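A few compounds are considered here, and "the series" means these few. Any claim that something is new, unique, unknown or untested is made for them only; others in the source may bear on it.

Measured so far:
Compound 1 `CC(c1cc2cccnc2cc1F)n1cnc2ncc(-c3cn[nH]c3)nc21`: 187 nM
Compound 2 `CC(c1cc2cccnc2cc1F)n1cnc2ncc(-c3cnn(CCO)c3)nc21`: 175 nM
Compound 3 `CC(c1c(F)cc2ncccc2c1F)n1cnc2ncc(-c3cnn(CCO)c3)nc21`: 83.7 nM

All three were tested in a functional assay on NCI-H1993 cells (Homo sapiens) for inhibition, read by CCK-8 assay, with a stated time of 72 h; a lower number here means a stronger inhibitor, a higher number a weaker inhibitor. Compound 2 cannot be told apart from compound 1, and one further change gives a 2.1-fold lower number from compound 2 to compound 3 (0.32 log units; beyond the scatter). Compound 4 `CC(c1cc2cccnc2cc1F)n1cnc2ncc(-c3ccncc3)nc21` has not yet been measured. It carries pyridin-4-yl in place of 1-(2-hydroxyethyl)-1H-pyrazol-4-yl on an aromatic carbon. The nearest evidence is a 1.1-fold lower number from compound 1 to compound 2 (0.03 log units; within the scatter), a change confined to the group on the aromatic nitrogen. Among the compounds with values here, the fluoro step lies elsewhere in the molecule, and no measured step replaces the ring itself. A small move towards a higher number is therefore expected, probably not beyond the scatter, and the expected step is a 1.6-fold higher number from compound 2 to compound 4 (0.20 log units; within the scatter). The estimated value for compound 4 is 280 nM, with an expected range of 90 nM to 900 nM.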

Compound 4, half-maximal inhibitory concentration: 171 nM
For compound 4 the middle estimate is 1.6-fold (0.21 log units) above the measured one; measured number inside the range.
By their numbers in this assay, from the lowest: compound 3; then compounds 4, 2 and 1 (each within the scatter of the next).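

In this assay the whole ring at this position proves exchangeable: pyridin-4-yl in place of 1-(2-hydroxyethyl)-1H-pyrazol-4-yl gives a 1.0-fold lower number from compound 2 to compound 4 (0.01 log units; within the scatter) and pyridin-4-yl in place of 1H-pyrazol-4-yl gives a 1.1-fold lower number from compound 1 to compound 4 (0.04 log units; within the scatter) in the same assay. The earlier compounds shown here altered only the group on the aromatic nitrogen, whereas here a five-membered ring gives way to a six-membered one, and compounds 1, 2 and 4 remain within the scatter of one another. No measurement at hand explains this. Open, on these data alone, is whether a longer chain on the aromatic nitrogen, or an amine or a carboxylic acid in place of the ring, would keep the number there. Also open, as far as these compounds go, is how the fluoro step of compound 3 would read alongside pyridin-4-yl.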